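The source may report more compounds than this note shows. Statements on the series, on what has been measured and on what is new or still open speak of the compounds shown alone.

In a functional assay on HT-29 cells (Homo sapiens) for cytotoxicity, read by sulforhodamine B assay (a higher number here means that more compound is tolerated, a lower number that less compound is tolerated), compound 1 `CC1=CC[C@@H]([C@@](C)(O)CCCC(C)(C)NC=S)CC1` gives 90300 nM. Compound 2 `CC1=CC[C@@H]([C@@](C)(O)CCCC(C)(C)NC(=S)N/N=C\c2ccc(O)cc2)CC1`, which carries a 4-hydroxyphenyl group on a carbon with a double bond to nitrogen, gives 58500 nM. These two numbers are the only ones available, and they lie within the usual scatter of each other, so compound 2 stands level with compound 1. For the measured compounds named here, the two measured compounds differ in more than one place, so no measured step shows what a single change does here.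

Compound 3 `CC1=CC[C@@H]([C@@](C)(O)CCCC(C)(C)NC(=S)N/N=C\c2ccccc2Cl)CC1` has not yet been measured. It differs from compound 2 in one place, with 2-chlorophenyl in place of 4-hydroxyphenyl on a carbon with a double bond to nitrogen. Going by the values given here, with no measured step as a guide, the expectation rests on compound 2 at 58500 nM, and no step beyond the scatter is expected in this assay. The estimated step is small, a 1.3-fold lower number from compound 2 to compound 3 (0.11 log units; within the scatter), and its direction is uncertain. For compound 3 the expected value is 45000 nM, with an estimated range from 18000 nM to 110000 nM.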

Compound 3, concentration lethal to 50% of the cells: > 100000 nM
Compound 3 ended at the assay's limit; the forecaster's own chance of this, stated with the estimate: 15%; middle value at least 2.2-fold (0.34 log units) away from the limit.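

For the compounds shown here, the change to 2-chlorophenyl in place of 4-hydroxyphenyl on a carbon with a double bond to nitrogen gives the only step in one place in this assay so far, an at least 1.7-fold higher number from compound 2 to compound 3 (0.23 log units; that floor lies within the scatter), and it shows that this swap does not bring a number lower than that of compound 2. In this assay compound 3 gives > 100000 nM, which is a limit of the assay and not a number. From the compounds shown here alone, the step can therefore be read only as a floor, and its true size stays unknown, because compound 3 sits at the limit: the limit of > 100000 nM in this assay, at which 1 of the 3 values shown sits.

The swap removes the hydroxyl and brings in a chlorine on the phenyl ring at once, so the compounds shown leave open which of the two goes with the reading at the limit. They also leave open how the series would read in this assay with a plain phenyl group, a 2-hydroxyphenyl group or a phenyl ring bearing an amine on that same carbon.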